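Lengthening the amine substituent on the shared core

The compounds below may be only part of what the source reports. "The series", "measured", "known", "first", "only" and "open" are said of these compounds alone.

Going by the values given here, compound 2 `CNC1=Nc2ccccc2C(C)N1` gives 103 nM in an assay on isolated protein for binding affinity to 5-hydroxytryptamine receptor 5A (Homo sapiens) (a higher number here means a weaker inhibitor, a lower number a stronger inhibitor), and stands lowest of the two numbers known, though compound 1 `CC1NC(NC2CCC2)=Nc2ccccc21` gives 122 nM and the only step known, a 1.2-fold lower number from compound 1 to compound 2 (0.07 log units; within the scatter), lies within the scatter. Compound 3 `CCCCNC1=Nc2ccccc2C(C)N1` differs from compound 2 by propyl in place of hydrogen on a saturated chain carbon bound to an amine nitrogen. That single measured step bears on this change: exchanging cyclobutyl for methyl on the amine nitrogen left the number essentially unchanged, so no step beyond the scatter in this assay is expected here, in either direction. The expected step is a 1.0-fold lower number from compound 2 to compound 3 (0.01 log units; within the scatter). Compound 3 is therefore estimated at 100 nM, within a range from 40 nM to 250 nM.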

Compound 3, inhibition constant: 189 nM
Estimate against measurement, compound 3: 1.9-fold (0.28 log units) below, within the range that was stated.
By their numbers in this assay, from the lowest: compounds 2, 1 and 3 (each within the scatter of the next).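

Extending the group on the amine nitrogen from methyl to butyl gives no step that can be told from the scatter in this assay: the reading is a 1.8-fold higher number from compound 2 to compound 3 (0.26 log units; within the scatter). Exchanging cyclobutyl for butyl on that nitrogen also stays within the scatter, with a 1.5-fold higher number from compound 1 to compound 3 (0.19 log units; within the scatter), so methyl, butyl and cyclobutyl cannot be separated at this position. No available evidence accounts for these numbers.

As far as these compounds go, whether a longer chain than butyl would move the number beyond the scatter remains open. So does the effect of a chain ending in an amine or a carboxylic acid.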